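Capping the hydroxy group of compound 1

The source may hold more compounds than are shown below. What is called first, only, known or untested is meant among the compounds shown, and "the series" means these compounds.

This story begins with compound 1 (`Cc1nn(-c2ccccc2)c2nc(O)c(-c3nc(N)cc(N)n3)cc12`), which carries a hydroxy group on its core. In a functional assay on aorta (Rattus norvegicus, strain Sprague-Dawley) (a lower number here means that less compound is needed, a higher number that more compound is needed for the effect), compound 1 has the entry "not determined" (no result reported) and so offers no number to start from. Compound 3 (`Cc1nn(-c2ccccc2)c2nc(OCc3ccc(C(F)(F)F)cc3)c(-c3nc(N)cc(N)n3)cc12`) is still waiting for its measurement. The structural change (4-(trifluoromethyl)benzyl in place of hydrogen on an oxygen on an aromatic ring) puts 4-(trifluoromethyl)benzyl in place of hydrogen on an oxygen on an aromatic ring, so the hydroxy becomes (4-(trifluoromethyl)benzyl)oxy.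

With nothing measured at the starting point, the size and direction of this step in this assay cannot be read from the data. For the measured compounds named here, the only real number comes from a third molecule, compound 2 (`Cc1nn(-c2ccccc2)c2nc(OCc3ccccc3F)c(-c3nc(N)c(N)c(N)n3)cc12`), and compound 2 gives 960 nM in that test. One value is thin support, so the expectation is simply that compound 3 lands in the same general region as compound 2, with no direction favoured and no gap beyond the usual scatter. Compound 3 is expected at about 800 nM as a working estimate. Its estimated range runs from 150 nM up to 4000 nM and is wide on purpose.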

Compound 3, half-maximal effective concentration: 1600 nM
Beside the measured number, compound 3's estimate is 2.0-fold (0.30 log units) below it; the range from low to high includes it.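

Compound 1 has no number in this assay, so the step to compound 3 cannot be read. No measured evidence is available to account for the result of compound 3. The compounds shown leave open whether turning the hydroxy into (4-(trifluoromethyl)benzyl)oxy changes the concentration needed, and if so, in which direction and by how much.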